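A few compounds are considered here, and "the series" means these few. Any claim that something is new, unique, unknown or untested is made for them only; others in the source may bear on it.

In a functional assay on MCF7 cells (Homo sapiens) for antiproliferative activity (on this read-out higher numbers stand for weaker inhibition and lower numbers for stronger inhibition), three compounds have been measured so far:

compound 1 `CC(=O)Oc1ccc2cc(-n3cc(-c4ccccc4)nn3)c(=O)oc2c1C` gives 40800 nM.
compound 2 `Cc1c(O)ccc2cc(-n3cc(-c4ccc(F)cc4F)nn3)c(=O)oc12` gives 33500 nM.
compound 3 `CC(=O)Oc1ccc2cc(-n3cc(-c4ccc(F)cc4F)nn3)c(=O)oc2c1C` gives only a limit of the assay, > 100000 nM.

Compound 3 thus stands at the weak end of the three: for it the assay reports no number, only a limit, so its true value is known only as a range (the limit of > 100000 nM in this assay, at which 1 of the 3 values shown sits). Two steps lead to it. The step of an at least 2.4-fold higher number from compound 1 to compound 3 (0.38 log units; beyond the scatter) shows that the 2,4-difluorophenyl group weakened the inhibition compared with plain phenyl, and the step of an at least 2.9-fold higher number from compound 2 to compound 3 (0.47 log units; beyond the scatter) shows the same direction when the hydroxyl hydrogen is replaced by acetyl.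

Compound 4 `COc1ccc(-c2cn(-c3cc4ccc(OC(C)=O)c(C)c4oc3=O)nn2)cc1` differs from compound 3 in one place: 4-methoxyphenyl in place of 2,4-difluorophenyl on an aromatic carbon. The step from compound 1 to compound 3 bears on this most directly, since it changed the same group on the same carbon, and it moved the number up. Removing the 2,4-difluorophenyl group again could be expected to bring compound 4 back toward the level of compound 1, whose 40800 nM sets a reference point. For compound 4 the expected step is an at least 1.6-fold lower number from compound 3 to compound 4 (0.22 log units; that floor lies within the scatter), a modest improvement that may still leave it near the limit. The estimate for compound 4 is therefore 60000 nM, ranging from 25000 nM to 150000 nM.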

Compound 4, half-maximal inhibitory concentration: > 100000 nM
Compound 4 gave a limit, no number; the forecaster's own chance of this, stated with the estimate: 40%; middle value at least 1.6-fold (0.22 log units) from the limit.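

In this assay compound 4 also gives only a limit of the assay, > 100000 nM. On this aromatic carbon of the five-membered ring, 4-methoxyphenyl, like 2,4-difluorophenyl before it, gives a weaker result than plain phenyl, with an at least 2.4-fold higher number from compound 1 to compound 4 (0.38 log units; beyond the scatter), so among the three acetyl compounds only the unsubstituted phenyl of compound 1 gives a measured number. The comparison between compound 3 and compound 4 cannot be read, so the two substituted phenyl groups cannot be ranked against each other, and both compounds sit at the same ceiling of the read-out: the limit of > 100000 nM in this assay, at which 2 of the 4 values shown sit.

Going by these compounds, it remains open whether 4-methoxyphenyl would give a number if the acetyl were replaced by hydrogen on the oxygen, as compound 2 does with its 2,4-difluorophenyl group. On these data alone, it is equally open whether a phenyl ring carrying an amine or a carboxylic acid at this carbon would stay near compound 1 or also fall to the limit.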